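A few compounds are considered here, and "the series" means these few. Any claim that something is new, unique, unknown or untested is made for them only; others in the source may bear on it.

Compound 1 `COCCOC(=O)NS(=O)(=O)c1sc(CC(C)C)cc1-c1ccc(Cn2ccnc2)cc1` — in an assay on membranes from liver for displacement of a labelled ligand from Type-2 angiotensin II receptor (Rattus norvegicus) (on this read-out lower numbers stand for stronger inhibition and higher numbers for weaker inhibition), compound 1 gives > 10000 nM, which is a limit of the assay and not a number.
Compound 2 `CC(C)Cc1cc(-c2ccc(Cn3ccnc3)cc2)c(S(=O)(=O)NC(=O)OC(C)C)s1` — in this assay compound 2 gives > 10000 nM, again only a limit.
Compound 3 `CC(C)Cc1cc(-c2ccc(Cn3ccnc3)cc2)c(S(=O)(=O)NC(=O)OC(C)(C)C)s1` — in this assay compound 3 gives > 10000 nM, again only a limit.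

Compound 3 therefore stands at the same limit as the other two; nothing in the numbers places it above or below them. The three measured steps cannot be read: a step that the two limits leave unreadable from compound 1 to compound 2, a step that the two limits leave unreadable from compound 1 to compound 3 and a step that the two limits leave unreadable from compound 2 to compound 3 are all hidden by the limit of > 10000 nM in this assay, at which 3 of the 3 values shown sit.

Compound 4 `CCCCS(=O)(=O)NS(=O)(=O)c1sc(CC(C)C)cc1-c1ccc(Cn2ccnc2)cc1` is yet to be measured. It differs from compound 3 in one place: butylsulfonyl in place of tert-butoxycarbonyl on a sulfonamide nitrogen. The measured steps all concern the alkyl portion of the carbamate, and none of them touches the sulfonamide nitrogen itself, so they bear on this change only in that every variant tried so far sits at the limit. On that basis no step beyond the scatter is expected in this assay, and the most likely outcome is again a limit. Compound 4 is expected at 10000 nM, within 3000 nM to 30000 nM, which means an expected step of a number no higher from compound 3 to compound 4 (the limit leaves the size open).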

Compound 4, inhibition constant: > 10000 nM
Compound 4: a limit, no number (the forecaster's own chance of this, stated with the estimate: 70%); the middle value sits exactly at the limit.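

The steps from compound 1, compound 2 and compound 3 to compound 4 cannot be read in this assay, because all four compounds stand at one limit: the limit of > 10000 nM in this assay, at which 4 of the 4 values shown sit.

The compounds shown leave open whether butylsulfonyl and the carbamate groups on the sulfonamide nitrogen differ at all on this read-out, and how weak each compound really is.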